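From 2-oxoimidazolidin-1-yl to carbamoylmethyl on a shared core

The compounds below may be only part of what the source reports. "The series", "measured", "known", "first", "only" and "open" are said of these compounds alone.

In an ADME assay on microsomes from liver (Mus musculus) for metabolic stability (a lower number here means that the compound disappears faster, a higher number that the compound lasts longer), compound 1 `CC(C)C(c1noc(=O)[nH]1)c1ccc(-c2ccc3cccc(F)c3c2)[nH]c1=O` gives > 3 h, which is a limit of the assay. For the measured compounds named here, compound 2 `CC(C)C(c1ccc(-c2ccc3cccc(F)c3c2)[nH]c1=O)N1CCNC1=O` gives 0.682 h, the only actual number so far. Compound 3 `CC(C)C(CC(N)=O)c1ccc(-c2ccc3cccc(F)c3c2)[nH]c1=O` changes the same saturated chain carbon: carbamoylmethyl in place of 2-oxoimidazolidin-1-yl on a saturated chain carbon bound to an aromatic carbon and a saturated chain carbon. Going by the values given here, one measured step bears on this, an at least 4.3-fold lower number from compound 1 to compound 2 (0.64 log units; beyond the scatter), and it lies beyond the scatter. That step swapped a different group, so it suggests that this carbon can matter but gives no direction here. The expected step, a 1.2-fold higher number from compound 2 to compound 3 (0.07 log units; within the scatter), stays within the scatter. Compound 3 is expected at 0.8 h, with an estimated range of 0.3 h to 2.5 h.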

Compound 3, half-life: < 0.0667 h
Compound 3 was reported as a limit; the forecaster's own chance of this, stated with the estimate: 10%; middle value at least 11-fold (1.07 log units) from the limit.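

In this assay, carbamoylmethyl on this saturated chain carbon gives an at least 10-fold lower number from compound 2 to compound 3 (1.00 log units; beyond the scatter), and an at least 44-fold lower number from compound 1 to compound 3 (1.65 log units; beyond the scatter). Compound 3 gives < 0.0667 h, which is a limit of the assay. So the group on this one carbon can shift the half-life strongly, and both compounds with a five-membered ring here last longer than the compound with the open chain.

The compounds shown leave open whether the ring as such or its particular atoms count. They also leave open how a carboxylic acid or a longer chain on this carbon would behave.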